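This account rests on a few compounds, and the source may have more. Where it says the series, first, only, none or still open, it means among the compounds named here.

Two triazenes have been tested in an ADME assay on MT4 cells (Homo sapiens) for cytotoxicity, read by MTT assay, with a stated time of 96 h; on this read-out higher numbers stand for lower toxicity in this test and lower numbers for higher toxicity in this test. Compound 1, `c1ccc(/N=N/N2CCN(c3ccccc3)CC2)cc1`, gives 33000 nM in this assay. Compound 2, `CN(C)CCCN(/N=N/c1ccc([N+](=O)[O-])cc1)c1ccccc1`, gives 20000 nM in this assay, and the two numbers lie within the scatter of each other, so neither compound can be set apart from the other on this read-out.

Compound 3, `CCOC(=O)N1CCN(/N=N/c2ccccc2)CC1`, has not yet been measured in this assay. It differs from compound 1 in one place: ethoxycarbonyl in place of phenyl on an amine nitrogen in a ring. Going by the values given here, nothing measured so far shows what an ethoxycarbonyl in place of a phenyl on the amine nitrogen in the ring does to this read-out, since no pair of measured compounds carries this change, and the one comparison available, between compound 1 and compound 2, shows no difference beyond the scatter.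

Among the compounds with values here, with no comparable step at hand, the change is expected to leave the number for compound 3 close to that of compound 1, with an expected step from compound 1 to compound 3 of a 1.2-fold higher number from compound 1 to compound 3 (0.08 log units; within the scatter), not clearly beyond the scatter in either direction. Compound 3 is therefore estimated to give 40000 nM in this assay, within a range of 15000 nM to 100000 nM.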

Compound 3, half-maximal cytotoxic concentration: 100000 nM
Compound 3: the middle estimate sits 2.5-fold (0.40 log units) below what was measured; measured number inside the range.
By their numbers in this assay, from the lowest: compounds 2 and 1 (each within the scatter of the next); then compound 3.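

The earlier compounds shown here offered no step at all at the amine nitrogen in the ring, and the pair of compound 1 and compound 3 now supplies the first. In this assay ethoxycarbonyl in place of phenyl gives a 3.0-fold higher number from compound 1 to compound 3 (0.48 log units; beyond the scatter) and so moves the number towards lower toxicity in this test, which shows that the group on this nitrogen can shift the read-out beyond the scatter, although this rests on a single modest step. The change swaps an aromatic ring of carbon only for a group with no ring and with hydrogen-bond acceptors, but nothing shown accounts for the step.

The compounds shown leave open which part of the ethoxycarbonyl goes with the higher number, a question that an acetyl, a methyl or a benzyl on the same nitrogen would help to answer. They also leave open whether the same change gives a step of similar size and direction when the phenyl on the other side of the triazene carries a substituent such as a nitro group.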